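Swapping Fluoro for Methoxy on a Sulfonyl-Bound Ring

This account rests on a few compounds, and the source may have more. Where it says the series, first, only, none or still open, it means among the compounds named here.

Going by the values given here, compound 2 `COc1ccc2ncc(S(=O)(=O)c3cccc(F)c3)c(N3CCC(C)CC3)c2c1` stands at the lower of the two numbers measured so far. In an assay on isolated protein for displacement of a labelled ligand from metabotropic glutamate receptor 5 (Homo sapiens), with a stated time of 60 min, tested at 1 uM (on this read-out higher numbers stand for more inhibition at the one concentration tested (going by the name of the read-out) and lower numbers for less inhibition), compound 2 gives 68%, while compound 1 `COc1ccc2ncc(S(=O)(=O)c3ccc(Cl)c(Cl)c3)c(N3CCC(C)CC3)c2c1` gives 87%. Among the compounds with values here, the single measured step, a number 19 percentage points lower from compound 1 to compound 2 (beyond the scatter), came with 3-fluorophenyl in place of 3,4-dichlorophenyl on a sulfonyl sulfur, a drop beyond the scatter.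

Compound 3 `COc1cccc(S(=O)(=O)c2cnc3ccc(OC)cc3c2N2CCC(C)CC2)c1` has not yet been measured. It differs from compound 2 by methoxy in place of fluoro on an aromatic carbon, on an aromatic carbon of a six-membered aromatic ring of carbon only, meta to a large group. Within the data shown here, no measured step swaps fluoro for methoxy, so that one step bears on it only loosely: it shows that the group on this ring can shift the read-out by a modest amount, without saying which way methoxy would go. For compound 3 the step is expected to be a number 2 percentage points higher from compound 2 to compound 3 (within the scatter), which is no change beyond the scatter. Compound 3 is therefore estimated at 70% in this assay, with a range from 50% to 88%.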

Compound 3, a percentage reported as inhibition, at one concentration (the size of the read-out at that concentration, not a potency): 0%
For compound 3 the middle estimate is 70 percentage points above the measured one; measured number outside the range, below it.
By their numbers in this assay, from the lowest: compound 3; then compound 2; then compound 1.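

At this place on the ring bound to the sulfonyl sulfur, the change of a single group can matter far more than the first pair suggested: in this assay, methoxy in place of fluoro gives a number 68 percentage points lower from compound 2 to compound 3 (beyond the scatter), whereas the earlier ring change gave only a number 19 percentage points lower from compound 1 to compound 2 (beyond the scatter). Measured against the 3,4-dichlorophenyl ring, the 3-methoxyphenyl ring gives a number 87 percentage points lower from compound 1 to compound 3 (beyond the scatter), which places compound 3 clearly lowest of the three and shows that a shared core and the same methylpiperidine-free comparison of ring groups do not by themselves preserve the read-out. Nothing available here explains why methoxy has this effect.

On these data alone, it remains open whether the loss is specific to methoxy or would also appear with other groups at this place, such as hydroxy, an amine, or a longer chain like ethoxy. Also open, as far as these compounds go, is whether a single chloro group would keep the higher inhibition seen with the 3,4-dichlorophenyl ring, or whether a carboxylic acid would behave differently from all three rings.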